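A few compounds are considered here, and "the series" means these few. Any claim that something is new, unique, unknown or untested is made for them only; others in the source may bear on it.

Measured so far:
- compound 1, `NC1CCN(C(=O)c2ccc(-c3ccc4ncc(-c5ccc6cnccc6c5)n4c3)cc2)CC1`: 16.8 nM
- compound 2, `O=C(c1ccc(-c2ccc3ncc(-c4ccc5ncccc5c4)n3c2)cc1)N1CCOCC1`: 371 nM

In an assay on Sf21 cells for inhibition of MAP kinase-interacting serine/threonine-protein kinase 1 (Homo sapiens), read by luminescence and ADP-Glo, with stated times of 10 min and 40 min (on this read-out lower numbers stand for stronger inhibition and higher numbers for weaker inhibition), compound 2 gives the highest number of the two, with compound 1 the nearest at a much lower number; the two differ in more than one place, so the gap says nothing about any single change. Compound 3, `O=C(c1ccc(-c2ccc3ncc(-c4cnc5ccccc5c4)n3c2)cc1)N1CCOCC1`, is not yet measured. It keeps the morpholine amide of compound 2 and differs only by quinolin-3-yl in place of quinolin-6-yl on an aromatic carbon. Going by the values given here, no pair in hand shows what rearranging the ring nitrogen of a quinolinyl group does at this position; compound 1 carries an isoquinolinyl group together with a different amide and is no guide to this step alone. A step of moderate size in either direction, or none beyond the scatter, is all that can be expected. As a working number compound 3 is estimated at 450 nM, with a range from 90 nM to 2500 nM, which means an expected step of a 1.2-fold higher number from compound 2 to compound 3 (0.08 log units; within the scatter) that is not committed to either direction.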

Compound 3, half-maximal inhibitory concentration: 154 nM
Beside the measured number, compound 3's estimate is 2.9-fold (0.47 log units) above it, within the range that was stated.
By their numbers in this assay, from the lowest: compound 1; then compound 3; then compound 2.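

In this assay, with the morpholine amide held constant, quinolin-3-yl in place of quinolin-6-yl gives a 2.4-fold lower number from compound 2 to compound 3 (0.38 log units; beyond the scatter). Going by these compounds alone, this is the first single-place reading, and it shows that this aromatic carbon of the five-membered ring responds to how the quinoline is joined, even though the entering and leaving groups have the same atoms and the same counts of donors and acceptors; the step is modest but beyond the scatter, and of these two groups quinolin-3-yl gives the lower number. Nothing measured on the compounds shown accounts for the difference between the two quinolinyl groups.

Within the data shown here, whether quinolin-3-yl would keep this standing with the amine-bearing amide of compound 1 remains open, as compound 1 differs from compound 3 in more than one place and gives no reading of this step. Also open, from the compounds shown here alone, is what a quinolin-4-yl group, or a naphthyl group with carbon only in both rings, would give at this position.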